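This account rests on a few compounds, and the source may have more. Where it says the series, first, only, none or still open, it means among the compounds named here.

Measured compounds:

compound 1, `CCCCCCCCCCn1cc(-c2nc3ccccc3cc2CCC)nn1`: > 100 ug/mL
compound 2, `CCc1cc2ccccc2nc1-c1cn(-c2ccc(F)cc2)nn1`: > 100 ug/mL
compound 3, `CCCCCc1cc2ccccc2nc1-c1cn(CCC(F)(F)C(F)(F)C(F)(F)C(F)(F)C(F)(F)C(F)(F)C(F)(F)C(F)(F)F)nn1`: > 100 ug/mL

These three compounds were tested in a functional assay on COLO 205 cells (Homo sapiens) for cytotoxicity, read by MTT assay, with a stated time of 24 h; a lower number here means a stronger inhibitor, a higher number a weaker inhibitor. For compound 2 the result is only a limit of the assay, not a measured number. The same holds for compound 1 and for compound 3, so every value seen so far sits at the limit of > 100 ug/mL in this assay, at which 3 of the 3 values shown sit, and no ordering among the three can be drawn.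

Compound 4, `CCCCCc1cc2ccccc2nc1-c1cn(-c2ccc(F)cc2)nn1`, is yet to be measured in this assay. It differs from compound 2 by propyl in place of hydrogen on a saturated chain carbon, two bonds along the chain from an aromatic carbon. For the measured compounds named here, no measured pair shows the effect of such a change here, so no step beyond the scatter is expected; compound 4 is most likely to return a limit again. The estimate for compound 4 in this assay is 150 ug/mL, within 40 ug/mL to 500 ug/mL, which means an expected step that the limit leaves unreadable from compound 2 to compound 4.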

Compound 4, half-maximal inhibitory concentration: > 100 ug/mL
Compound 4: no number, only a limit; the forecaster's own chance of this, stated with the estimate: 85%; the middle value is on the limit's open side.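

Compound 2 and compound 4 both give only a limit, so no step between them can be read: the limit of > 100 ug/mL in this assay, at which 4 of the 4 values shown sit.

The compounds shown leave open what actual number any of them would reach in this assay, and so whether swapping hydrogen for propyl changes anything.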